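The source may report more compounds than this note shows. Statements on the series, on what has been measured and on what is new or still open speak of the compounds shown alone.

Of the compounds shown here, three have been measured so far in a physicochemical assay for lipophilicity, read by HPLC, measured as chromatographic lipophilicity, at pH 7.4 (on this read-out lower numbers stand for lower lipophilicity and higher numbers for higher lipophilicity), and give these values.

compound 1 `O=C(C1CCN(c2ccncn2)CC1)N1N=CC[C@H]1c1ccccc1` at 3.2
compound 2 `O=C(C1CCOC1)N1N=CCC1c1ccccc1` at 3
compound 3 `CC(C)(C)C(=O)N1N=CCC1c1cccnc1` at 3.2

Compound 2 lies within the usual scatter of both compound 1 and compound 3, so these three numbers cannot be told apart. The next compound to be measured is compound 4 `O=C(C1CCCCC1)N1N=CCC1c1ccccc1`, which carries cyclohexyl in place of oxolan-3-yl on a carbonyl carbon. Within the data shown here, no pair of measured compounds shows this change, so the expectation rests on the structural change alone, starting from compound 2 (3). The estimated step of a number 1.00 log units higher from compound 2 to compound 4 (beyond the scatter) is expected to be upward and beyond the scatter in this assay for this series. Compound 4 is expected at 4 with a likely range from 3.5 to 4.5 on this scale.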

Compound 4, distribution coefficient: 5.9
Compound 4: the middle estimate sits 1.90 log units below what was measured; the measured number lies above the stated range.
By their numbers in this assay, from the lowest: compounds 2, 1 and 3 (each within the scatter of the next); then compound 4.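

Among these compounds, exchanging oxolan-3-yl for cyclohexyl on this carbonyl carbon gives a number 2.90 log units higher from compound 2 to compound 4 (beyond the scatter) in this assay, so this position can move the read-out far beyond anything the earlier compounds showed. The entering ring differs from the leaving one both in size and in having carbon only, and this single step cannot separate those two differences. Nothing measured here explains the size of the step. Where cyclopentyl, with a five-membered ring of carbon only, or oxan-4-yl, with a six-membered ring holding oxygen, would fall remains open.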